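A Benzyl Swap on a Shared Core, Antiproliferative Readout

A few compounds are considered here, and "the series" means these few. Any claim that something is new, unique, unknown or untested is made for them only; others in the source may bear on it.

Within the data shown here, compound 1 `OC[C@H]1O[C@@H](n2cnc3c(NCc4ccc(F)cc4)ncnc32)[C@H](O)[C@@H]1O` is the only measured member of this small set. In a functional assay on G-361 cells (Homo sapiens) for antiproliferative activity, with a stated time of 72 h (a higher number here means a weaker inhibitor, a lower number a stronger inhibitor), compound 1 gives > 166000 nM, which is a limit of the assay rather than a number. A second compound, compound 2 `Cc1ccc(CNc2ncnc3c2ncn3[C@@H]2O[C@H](CO)[C@@H](O)[C@H]2O)cc1`, was tested in this assay but no result is reported for it, "not determined" (no result reported). Compound 3 `COc1ccccc1CNc1ncnc2c1ncn2[C@@H]1O[C@H](CO)[C@@H](O)[C@H]1O` has not yet been measured; it differs from compound 1 in one place, (2-methoxyphenyl in place of 4-fluorophenyl on a saturated chain carbon bound to a nitrogen on an aromatic ring). Among the measured compounds shown here, no pair of measured compounds differs in a single place, so the size of a step of this kind cannot be read from the data; the only anchor is the limit of > 166000 nM in this assay, at which 1 of the 2 values shown sits. Because compound 1 sits at the limit of > 166000 nM in this assay, at which 1 of the 2 values shown sits, the step of an at least 1.1-fold lower number from compound 1 to compound 3 (0.04 log units; that floor lies within the scatter) is expected to stay within the scatter, with a fair chance that this assay again reports only a limit. Compound 3 is therefore expected to give 150000 nM in this assay, with a range from 40000 nM to 500000 nM.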

Compound 3, half-maximal inhibitory concentration: > 166000 nM
Compound 3 ended at the assay's limit (the forecaster's own chance of this, stated with the estimate: 60%); middle value at least 1.1-fold (0.04 log units) away from the limit.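

Compound 1 and compound 3 each reach only a limit of the assay and give no number, so no step between them can be read in this assay: the limit of > 166000 nM in this assay, at which 2 of the 3 values shown sit.

The compounds shown leave open whether 4-fluorobenzyl and 2-methoxybenzyl differ at all in this assay, and whether any change on the shared core would give a readable number there.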